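This account rests on a few compounds, and the source may have more. Where it says the series, first, only, none or still open, it means among the compounds named here.

Compound 1 `Cn1cc(/C=C/C(=O)c2cccc(Cl)c2)cc1/C=C/C(=O)NO` gives 31400 nM in an assay on isolated protein for inhibition of histone deacetylase HD1B (Zea mays); on this read-out higher numbers stand for weaker inhibition and lower numbers for stronger inhibition.
Compound 2 `Cn1cc(/C=C/C(=O)c2ccc(F)cc2)cc1/C=C/C(=O)NO` gives 24900 nM in this assay.
Compound 3 `COc1cccc(C(=O)/C=C/c2cc(/C=C/C(=O)NO)n(C)c2)c1` gives 600 nM in this assay.

Compound 3 is the strongest inhibitor of the three, since both steps to it are beyond the scatter: a 52-fold lower number from compound 1 to compound 3 (1.72 log units; beyond the scatter) and a 42-fold lower number from compound 2 to compound 3 (1.62 log units; beyond the scatter). The step between compound 1 and compound 2 is small, a 1.3-fold lower number from compound 1 to compound 2 (0.10 log units; within the scatter), so the low number of compound 3 rests on its 3-methoxyphenyl group. Compound 4 `Cn1cc(/C=C/C(=O)c2cccs2)cc1/C=C/C(=O)NO` differs from compound 3 by thiophen-2-yl in place of 3-methoxyphenyl on a carbonyl carbon. Both large measured steps bear on this change, as each alters the same aryl group on the carbonyl carbon, and compound 4 no longer carries the methoxy that set compound 3 apart. Compound 4 is therefore expected to give a higher number in this assay, estimated at 8000 nM (range 1500 nM to 40000 nM), a step of a 13-fold higher number from compound 3 to compound 4 (1.12 log units; beyond the scatter).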

Compound 4, half-maximal inhibitory concentration: 25800 nM
Estimate against measurement, compound 4: 3.2-fold (0.51 log units) below; low and high end bracket the measured number.
By their numbers in this assay, from the lowest: compound 3; then compounds 2, 4 and 1 (each within the scatter of the next).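

At the carbonyl carbon, thiophen-2-yl in place of 3-methoxyphenyl gives a 43-fold higher number from compound 3 to compound 4 (1.63 log units; beyond the scatter), while thiophen-2-yl in place of 4-fluorophenyl gives a 1.0-fold higher number from compound 2 to compound 4 (0.02 log units; within the scatter) and in place of 3-chlorophenyl gives a 1.2-fold lower number from compound 1 to compound 4 (0.09 log units; within the scatter). Among these four groups, only 3-methoxyphenyl therefore stands apart in this assay, and the other three, including the five-membered sulfur ring, lie within the scatter of each other. Nothing available explains why this group stands apart. As far as these compounds go, it remains open whether the low number of compound 3 would survive an ethoxy or hydroxyl group in place of the methoxy.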